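Nitro for chloro on the aryl ring of compound 1

The source may report more compounds than this note shows. Statements on the series, on what has been measured and on what is new or still open speak of the compounds shown alone.

Compound 1 `CC(=O)c1nn(-c2ccc(Cl)cc2)/c(=N/c2nc(-c3c(C)n(C)n(-c4ccccc4)c3=O)cs2)s1` reaches only a limit in a functional assay on HepG2 cells (Homo sapiens) for cytotoxicity, read by sulforhodamine B assay, with a stated time of 72 h; a higher number here means a weaker inhibitor, a lower number a stronger inhibitor: compound 1 gives > 100000 nM, which is a limit of the assay and not a number (the limit of > 100000 nM in this assay, at which 1 of the 2 values shown sits). Compound 2 `COc1ccc(-n2nc(C(C)=O)s/c2=N\c2nc(-c3c(C)n(C)n(-c4ccccc4)c3=O)cs2)cc1` carries methoxy in place of chloro on that aromatic carbon; in this assay compound 2 gives 41300 nM. For the measured compounds named here, the step of an at least 2.4-fold lower number from compound 1 to compound 2 (0.38 log units; beyond the scatter) is the only measured change, and it starts from a limit, so its true size is open.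

Compound 3 `CC(=O)c1nn(-c2ccc([N+](=O)[O-])cc2)/c(=N/c2nc(-c3c(C)n(C)n(-c4ccccc4)c3=O)cs2)s1` differs from compound 1 by nitro in place of chloro on an aromatic carbon. Going by the values given here, no measured step covers nitro at this position; the single measured replacement at the same carbon, an at least 2.4-fold lower number from compound 1 to compound 2 (0.38 log units; beyond the scatter), points to at most a modest move toward lower numbers. For compound 3 a small step in that direction, or none beyond the scatter, is expected, with a real chance that only a limit is returned again. Compound 3 is expected at 80000 nM, within 25000 nM to 250000 nM. That estimate corresponds to an expected step of an at least 1.2-fold lower number from compound 1 to compound 3 (0.09 log units; that floor lies within the scatter).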

Compound 3, half-maximal inhibitory concentration: > 100000 nM
Compound 3 was reported as a limit; the forecaster's own chance of this, stated with the estimate: 45%; middle value at least 1.2-fold (0.09 log units) from the limit.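

Compound 3 returns a limit and not a number in this assay: the limit of > 100000 nM in this assay, at which 2 of the 3 values shown sit.

Nitro in place of methoxy gives an at least 2.4-fold higher number from compound 2 to compound 3 (0.38 log units; beyond the scatter), so the lower number of compound 2 does not extend to every replacement of chloro at this aromatic carbon, and methoxy remains the only group here with a measured number. The steps between the two limits cannot be read, so the change from 4-chlorophenyl to 4-nitrophenyl has no readable size or direction.

From the compounds shown here alone, how far the true values of compound 1 and compound 3 lie beyond the limit remains open, and with it any order between chloro and nitro. Also open, going by these compounds, is whether an amine or a hydroxyl on this carbon would give a measurable number, as methoxy does in compound 2.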